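The source may report more compounds than this note shows. Statements on the series, on what has been measured and on what is new or still open speak of the compounds shown alone.

Measured in an ADME assay on the whole organism (strain FVB) for pharmacokinetics, with Mus musculus as the target, read by LC-MS, at a dose of 30 mg/kg by the oral route; on this read-out higher numbers stand for higher exposure at the dose given and lower numbers for lower exposure:
- compound 1 `c1cc([C@H]2CC[C@]3(CC2)OOC2(O3)C3CC4CC(C3)CC2C4)ccc1OCCOC1CCNCC1`: 9180 ng.h/mL
- compound 2 `CC(C)(O)CNCCCOc1ccc([C@H]2CC[C@]3(CC2)OOC2(O3)C3CC4CC(C3)CC2C4)cc1`: 11100 ng.h/mL

Compound 2, at 11100 ng.h/mL, sits within the scatter of compound 1, with a 1.2-fold higher number from compound 1 to compound 2 (0.08 log units; within the scatter). Compound 3 `c1cc([C@H]2CC[C@]3(CC2)OOC2(O3)C3CC4CC(C3)CC2C4)ccc1OC1CCNCC1` differs from compound 2 as follows: piperidin-4-yl in place of 3-((2-hydroxy-2-methylpropyl)amino)propyl on an oxygen on an aromatic ring. Among the compounds with values here, the only measured step is a 1.2-fold higher number from compound 1 to compound 2 (0.08 log units; within the scatter). Within the data shown here, it changes the chain further out and leaves the chain on the oxygen in place, so it bears only indirectly, and no measured step covers this change. No shift beyond the scatter is therefore expected, with wide uncertainty. The estimate is a 1.4-fold lower number from compound 2 to compound 3 (0.14 log units; within the scatter). For compound 3 the expected value is 8000 ng.h/mL, within an estimated range of 2500 ng.h/mL to 25000 ng.h/mL.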

Compound 3, area under the concentration-time curve: 7200 ng.h/mL
Estimate against measurement, compound 3: 1.1-fold (0.05 log units) above; low and high end bracket the measured number.
By their numbers in this assay, from the lowest: compounds 3, 1 and 2 (each within the scatter of the next).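

On the oxygen on the aromatic ring, the substituent can be cut back to piperidin-4-yl with no shift beyond the scatter in this assay: a 1.5-fold lower number from compound 2 to compound 3 (0.19 log units; within the scatter) and a 1.3-fold lower number from compound 1 to compound 3 (0.11 log units; within the scatter) are both small. Neither the 3-((2-hydroxy-2-methylpropyl)amino)propyl chain nor the 2-((piperidin-4-yl)oxy)ethyl chain separates from the directly attached ring on this read-out. Nothing available gives a reason for this result. Open, from the compounds shown here alone, is whether a carboxylic acid on this oxygen, or a methyl group on the piperidine nitrogen, would leave exposure equally unmoved.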